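Three carbonyl substituents on one core, and a fourth to come

This account rests on a few compounds, and the source may have more. Where it says the series, first, only, none or still open, it means among the compounds named here.

Compound 1 `CCn1c(C(=O)NCC(OC)OC)ccc1C(CC)(CC)c1ccc(OCC(=O)C(C)(C)C)c(C)c1` gives 130 nM in an assay on HL-60 cells for agonist activity at vitamin D3 receptor (Homo sapiens), read by microscopy, with a stated time of 96 h; a lower number here means that less compound is needed, a higher number that more compound is needed for the effect. Compound 2 `CCn1c(C(=O)N(C)CCC#N)ccc1C(CC)(CC)c1ccc(OCC(=O)C(C)(C)C)c(C)c1` gives 9800 nM. Compound 3 `CCn1c(C(=O)N(CCC#N)CCC#N)ccc1C(CC)(CC)c1ccc(OCC(=O)C(C)(C)C)c(C)c1` gives 870 nM.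

Compound 3 therefore stands second highest of the three numbers: the step of a 6.7-fold higher number from compound 1 to compound 3 (0.83 log units; beyond the scatter) separates it from compound 1, and the step of an 11-fold lower number from compound 2 to compound 3 (1.05 log units; beyond the scatter) from compound 2. Compound 4 `C#CC(C)OC(=O)c1ccc(C(CC)(CC)c2ccc(OCC(=O)C(C)(C)C)c(C)c2)n1CC` is not yet measured; it carries a group of 5 heavy atoms (4 carbon, 1 oxygen; no ring) in place of a group of 9 heavy atoms (6 carbon, 3 nitrogen; no ring), on a carbonyl carbon. Both measured steps touch the same carbonyl substituent and both were beyond the scatter, one modest and one large, so a change at this position is expected to move this assay well beyond the scatter again. The direction is open, as no ester has been measured. For compound 4 the expected step is a 5.8-fold lower number from compound 3 to compound 4 (0.76 log units; beyond the scatter), giving an estimate of 150 nM with a range from 30 nM to 1500 nM.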

Compound 4, half-maximal effective concentration: 210 nM
Estimate against measurement, compound 4: 1.4-fold (0.15 log units) below, within the range that was stated.
By their numbers in this assay, from the lowest: compounds 1 and 4 (each within the scatter of the next); then compound 3; then compound 2.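

The (1-methylprop-2-yn-1-yl)oxy group shows that an ester on this carbonyl carbon can stand in for the amides in this assay: the steps are a 4.1-fold lower number from compound 3 to compound 4 (0.62 log units; beyond the scatter) and a 47-fold lower number from compound 2 to compound 4 (1.67 log units; beyond the scatter), while a 1.6-fold higher number from compound 1 to compound 4 (0.21 log units; within the scatter) leaves it level with the (2,2-dimethoxyethyl)amino amide. A nitrogen on this carbonyl carbon is therefore not needed for a number of that size. Nothing measured here accounts for these steps. Still open, going by these compounds, is how a carboxylic acid, a simple ethyl ester or a longer alkynyl chain at this carbonyl carbon would compare.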